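A few compounds are considered here, and "the series" means these few. Any claim that something is new, unique, unknown or untested is made for them only; others in the source may bear on it.

Measured compounds:
Compound 1, `COc1ccc2cc(C(C)c3nnc4n3N=C(c3ccc(Cl)cc3Cl)CS4)ccc2c1`: 14600 nM
Compound 2, `CC(c1ccc(-c2ccccc2)c(F)c1)c1nnc2n1N=C(c1ccc(C(F)(F)F)cc1)CS2`: 4300 nM
Compound 3, `CC(C)Cc1ccc(C(C)c2nnc3n2N=C(c2ccc(Br)cc2)CS3)cc1`: 9400 nM

All three compounds share a common core and were tested in a functional assay on MCF7 cells (Homo sapiens) for inhibition, read by sulforhodamine B assay, with a stated time of 72 h; a lower number here means a stronger inhibitor, a higher number a weaker inhibitor. Compound 2 gives the lowest of the three numbers. The nearest to it is compound 3, whose value of 9400 nM lies beyond the scatter above it, and the furthest is compound 1, which gives 14600 nM. Neither of these pairs differs from compound 2 in a single place, so their gaps cannot be tied to one structural change.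

Compound 4, `CC(c1ccc(-c2ccccc2)c(F)c1)c1nnc2n1N=C(c1ccc(Br)cc1)CS2`, does differ from compound 2 in exactly one place: bromo in place of trifluoromethyl on an aromatic carbon. No measured pair isolates this change, so the account can only reason from the three numbers shown. Among them, compound 3 carries the bromo group yet sits at a higher number than compound 2, though its other aryl group also differs. Taken together, the expected step of a 1.3-fold higher number from compound 2 to compound 4 (0.11 log units; within the scatter) is small, most likely within the scatter, with a slight lean toward a higher number. In this assay compound 4 is therefore estimated to give 5500 nM, with a range from 2500 nM to 12000 nM.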

Compound 4, half-maximal inhibitory concentration: 7400 nM
The estimate for compound 4 lay 1.3-fold (0.13 log units) below the measured number; the range from low to high includes it.
By their numbers in this assay, from the lowest: compounds 2, 4, 3 and 1 (each within the scatter of the next, the first and the last beyond it).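

For the compounds shown here, compound 2 and compound 4 give the first direct reading of this position in this assay, as the earlier compounds all differed in more than one place. With everything else held the same, exchanging 4-(trifluoromethyl)phenyl for 4-bromophenyl gives a 1.7-fold higher number from compound 2 to compound 4 (0.24 log units; within the scatter) in this assay. On this aromatic carbon, para to a large group, 4 heavy atoms can thus give way to 1 without the two compounds being told apart, and the pair offers no sign that this position favours either group.

Going by these compounds alone, whether the exchange reads the same alongside the other aryl groups, such as the one in compound 3, remains open, since this single pair shares one background. As far as these compounds go, how a nitrile, an amine or a carboxylic acid would read at this aromatic carbon also remains open, so the tolerance seen here covers only trifluoromethyl and bromo. Nothing shown here offers an explanation for this reading.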